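A few compounds are considered here, and "the series" means these few. Any claim that something is new, unique, unknown or untested is made for them only; others in the source may bear on it.

Compound 1 `CC1=C(C(=O)OCC2CC2)C(c2ccco2)NC(=O)N1` gives 138 nM in an assay on membranes from HEK293 cells for displacement of a labelled ligand from adenosine receptor A2b (Homo sapiens), read by scintillation counting, with a stated time of 30 min; on this read-out higher numbers stand for weaker inhibition and lower numbers for stronger inhibition. Compound 2 `CC1=C(C(=O)OCC2CCC2)C(c2ccco2)NC(=O)N1` differs from it by cyclobutyl in place of cyclopropyl on a saturated chain carbon bound to an oxygen next to a carbonyl group, and compound 2 gives 561 nM in this assay, a step of a 4.1-fold higher number from compound 1 to compound 2 (0.61 log units; beyond the scatter). Compound 3 `CC1=C(C(=O)OCC2CC2)C(c2cccs2)NC(=O)N1` has a different core: it differs from compound 1 by thiophen-2-yl in place of furan-2-yl on a saturated ring carbon. In this assay compound 3 gives 1570 nM, a step of an 11-fold higher number from compound 1 to compound 3 (1.06 log units; beyond the scatter), and it has the highest number of the three.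

Compound 4 `CC1=C(C(=O)OCC2CCC2)C(c2cccs2)NC(=O)N1` is not yet measured. It differs from compound 3 by cyclobutyl in place of cyclopropyl on a saturated chain carbon bound to an oxygen next to a carbonyl group, the same change that was made from compound 1 to compound 2, made at the same place on the other core. Because the step of a 4.1-fold higher number from compound 1 to compound 2 (0.61 log units; beyond the scatter) was modest, a step of similar size is expected here, so that compound 4 is expected to give about 6000 nM in this assay, an estimated step of a 3.8-fold higher number from compound 3 to compound 4 (0.58 log units; beyond the scatter).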

Compound 4, inhibition constant: 2840 nM
The estimate for compound 4 lay 2.1-fold (0.32 log units) above the measured number, within the range that was stated.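

In this assay, cyclobutyl in place of cyclopropyl gives a 1.8-fold higher number from compound 3 to compound 4 (0.26 log units; within the scatter), and the two steps for this change cannot be told apart: the same change on two cores in this assay, a 4.1-fold higher number (0.61 log units; beyond the scatter) from compound 1 to compound 2 and a 1.8-fold higher number (0.26 log units; within the scatter) from compound 3 to compound 4, 2.2-fold (0.35 log units) apart, within the scatter of two such steps. Thiophen-2-yl in place of furan-2-yl gives a 5.1-fold higher number from compound 2 to compound 4 (0.70 log units; beyond the scatter), and again the two steps cannot be told apart: the same change on two cores in this assay, an 11-fold higher number (1.06 log units; beyond the scatter) from compound 1 to compound 3 and a 5.1-fold higher number (0.70 log units; beyond the scatter) from compound 2 to compound 4, 2.2-fold (0.35 log units) apart, within the scatter of two such steps. Each change therefore carries between these two cores within the scatter, but one pair of steps per change does not show that it would hold on any other core.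

The compounds shown leave open what a longer chain in place of cyclopropylmethyl would give. They also leave open what a phenyl group in place of furan-2-yl would give.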